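Bromophenyl in Place of Methylphenyl on a Thiosemicarbazone

The source may hold more compounds than are shown below. What is called first, only, known or untested is meant among the compounds shown, and "the series" means these compounds.

The compounds here share one core and differ only in the group on the amide-type nitrogen whose other neighbour is the thiocarbonyl carbon. Compound 1 `NC(=S)N/N=C/c1ccc2ccccc2n1` carries hydrogen there, and in a functional assay on HeLa cells (Homo sapiens) for antiproliferative activity, read by sulforhodamine B assay, with a stated time of 72 h (on this read-out higher numbers stand for weaker inhibition and lower numbers for stronger inhibition), compound 1 gives 960 nM. Compound 2 `Fc1cccc(NC(=S)N/N=C/c2ccc3ccccc3n2)c1` carries 3-fluorophenyl, and in this assay compound 2 gives 70100 nM. Compound 3 `Cc1ccccc1NC(=S)N/N=C/c1ccc2ccccc2n1` carries 2-methylphenyl. In this assay compound 3 gives > 100000 nM, which is a limit of the assay rather than a number. Compound 3 therefore sits at the limit of > 100000 nM in this assay, at which 1 of the 3 values shown sits.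

The measured steps are a 73-fold higher number from compound 1 to compound 2 (1.86 log units; beyond the scatter) and an at least 100-fold higher number from compound 1 to compound 3 (2.01 log units; beyond the scatter), both large, whereas an at least 1.4-fold higher number from compound 2 to compound 3 (0.15 log units; that floor lies within the scatter).

Compound 4 `S=C(N/N=C/c1ccc2ccccc2n1)Nc1cccc(Br)c1` is the next member: 3-bromophenyl in place of 2-methylphenyl on an amide-type nitrogen. Compound 4 thus carries a halogen-bearing phenyl like compound 2, and since the step from compound 1 to compound 2 was a 73-fold higher number from compound 1 to compound 2 (1.86 log units; beyond the scatter) while the step from compound 2 to compound 3 was an at least 1.4-fold higher number from compound 2 to compound 3 (0.15 log units; that floor lies within the scatter), a number near that of compound 2 is expected, with a fair chance that only a limit is reported again. Compound 4 is expected to show an at least 1.2-fold lower number from compound 3 to compound 4 (0.09 log units; that floor lies within the scatter). Compound 4 is estimated at 80000 nM, with a range from 25000 nM to 250000 nM.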

Compound 4, half-maximal inhibitory concentration: 70000 nM
Compound 4: the middle estimate sits 1.1-fold (0.06 log units) above what was measured; measured number inside the range.
By their numbers in this assay, from the lowest: compound 1; then compounds 4 and 2 (each within the scatter of the next). At a limit, above all of these: compound 3.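

Exchanging fluoro for bromo on the aromatic carbon leaves the read-out where it was, with a 1.0-fold lower number from compound 2 to compound 4 (0.00 log units; within the scatter), so 3-fluorophenyl and 3-bromophenyl cannot be told apart in this assay. The large rise seen on replacing hydrogen on the amide-type nitrogen with a phenyl group now appears with a second halogen-bearing phenyl, at a 73-fold higher number from compound 1 to compound 4 (1.86 log units; beyond the scatter), and all three phenyl-bearing compounds shown follow this pattern, with none going against it. The comparison with 2-methylphenyl gives only a floor, an at least 1.4-fold lower number from compound 3 to compound 4 (0.15 log units; that floor lies within the scatter), so 3-bromophenyl and 2-methylphenyl cannot be ranked, and compound 3 holds a limit of the assay rather than a number: the limit of > 100000 nM in this assay, at which 1 of the 4 values shown sits.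

From the compounds shown here alone, what a methyl or ethyl group on this nitrogen would give, in place of a phenyl ring, stays open, and so does how close such a group would come to the number of compound 1. Going by these compounds, it is also open whether a phenyl ring carrying an amine or a carboxylic acid would give a number different from those of the two halogen-bearing phenyl compounds.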